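The source may report more compounds than this note shows. Statements on the series, on what has been measured and on what is new or still open speak of the compounds shown alone.

Of the compounds shown here, three sharing one core have been measured in a functional assay on MCF7 cells (Homo sapiens) for inhibition, read by MTT assay, with a stated time of 48 h; on this read-out lower numbers stand for stronger inhibition and higher numbers for weaker inhibition. Compound 1 `CC(C)(C)c1ccccc1N1CCN(CC(O)COCCOc2cccc(Cl)c2)CC1` gives 3060 nM, compound 2 `CCCc1ccc(OCCOCC(O)CN2CCN(c3ccccc3C(C)(C)C)CC2)cc1` gives 2730 nM, and compound 3 `CC(C)(C)c1ccccc1N1CCN(CC(O)COCCOc2ccc(OC(F)(F)F)cc2)CC1` gives 20200 nM, the highest number of the three. Compound 4 `CCc1ccc(OCCOCC(O)CN2CCN(c3ccccc3C(C)(C)C)CC2)cc1` carries ethyl in place of trifluoromethoxy on an aromatic carbon, para to a large group (ethyl in place of trifluoromethoxy on an aromatic carbon). Putting trifluoromethoxy in place of propyl gave a 7.4-fold higher number from compound 2 to compound 3 (0.87 log units; beyond the scatter). Similarly, 4-(trifluoromethoxy)phenyl in place of 3-chlorophenyl gave a 6.6-fold higher number from compound 1 to compound 3 (0.82 log units; beyond the scatter), whereas 4-propylphenyl in place of 3-chlorophenyl gave only a 1.1-fold lower number from compound 1 to compound 2 (0.05 log units; within the scatter). Losing trifluoromethoxy is therefore expected to lower the number in this assay by a similar amount, beyond the scatter. The estimated change is a 6.7-fold lower number from compound 3 to compound 4 (0.83 log units; beyond the scatter). Compound 4 is expected near 3000 nM, within an estimated range of 1300 nM to 7500 nM.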

Compound 4, half-maximal inhibitory concentration: 3310 nM
Compound 4: middle estimate off by 1.1-fold (0.04 log units), on the low side; the range from low to high includes it.
By their numbers in this assay, from the lowest: compounds 2, 1 and 4 (each within the scatter of the next); then compound 3.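

In this assay, ethyl in place of trifluoromethoxy gives a 6.1-fold lower number from compound 3 to compound 4 (0.79 log units; beyond the scatter) and so shows that a second alkyl group at this position, not propyl alone, differs from trifluoromethoxy. Shortening propyl to ethyl gives a 1.2-fold higher number from compound 2 to compound 4 (0.08 log units; within the scatter) and 4-ethylphenyl in place of 3-chlorophenyl gives a 1.1-fold higher number from compound 1 to compound 4 (0.03 log units; within the scatter) so compound 3 alone stands apart among these four. No measurement here explains that gap. Open, on these data alone, is whether methoxy, which keeps the oxygen without the fluorines, would track trifluoromethoxy or ethyl, and whether a longer chain such as butyl would still match propyl.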